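The source may hold more compounds than are shown below. What is called first, only, known or untested is meant among the compounds shown, and "the series" means these compounds.

Measured compounds, each reported only as a limit in a functional assay on SV5A8 cells (Homo sapiens) for cytotoxicity; on this read-out lower numbers stand for stronger inhibition and higher numbers for weaker inhibition:
Compound 1, `Cc1ccc2c(NCc3ccc(NC(=O)C4CCN(Cc5ccccc5)CC4)cc3)nc(N3CCN[C@@H](C)C3)nc2c1`: > 8860 nM
Compound 2, `Cc1ccc2c(NCc3ccc(NC(=O)C4CCN(Cc5ccccc5)CC4)cc3)nc(N3CCC(N4CCCC4)CC3)nc2c1`: > 8090 nM
Compound 3, `Cc1ccc2c(NCc3ccc(NC(=O)C4CCN(Cc5ncc[nH]5)CC4)cc3)nc(N(C)C)nc2c1`: > 20000 nM

Compound 1 stands at a limit of the assay, not at a number, and the same holds for each other compound shown. For the measured compounds named here, the only single-point step measured is a step that the two limits leave unreadable from compound 1 to compound 2, and its size cannot be read. Compound 4, `Cc1ccc2c(NCc3ccc(NC(=O)C4CCN(Cc5ccccc5)CC4)cc3)nc(N3CCNC(CCO)C3)nc2c1`, differs from compound 1 by 3-(2-hydroxyethyl)piperazin-1-yl in place of 3-methylpiperazin-1-yl on an aromatic carbon. Going by the values given here, no measured step bears on this change; the series offers only (the limit of > 8860 nM in this assay, at which 1 of the 3 values shown sits), the limit of > 8090 nM in this assay, at which 1 of the 3 values shown sits, and (the limit of > 20000 nM in this assay, at which 1 of the 3 values shown sits), all limits. The step that the limit leaves unreadable from compound 1 to compound 4 is expected to stay within scatter. Compound 4 is therefore expected to return another limit, estimated at 15000 nM with a range of 5000 nM to 50000 nM.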

Compound 4, half-maximal inhibitory concentration: > 8420 nM
Compound 4: no number, only a limit (the forecaster's own chance of this, stated with the estimate: 80%); the middle value does not contradict the limit.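

Compound 1, compound 2 and compound 4 all stand as limits in this assay, and the steps from compound 1 to compound 4 and from compound 2 to compound 4 cannot be read. The compounds shown leave open whether changing the group at this place shifts the read-out at all, as none of them gives a number.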